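Amine substituent variation in a diaryl ether anilino series

A few compounds are considered here, and "the series" means these few. Any claim that something is new, unique, unknown or untested is made for them only; others in the source may bear on it.

Measured so far in a functional assay on HT-29 cells (Homo sapiens) for inhibition, read by MTT assay, with a stated time of 72 h; on this read-out higher numbers stand for weaker inhibition and lower numbers for stronger inhibition:
compound 1, `COc1ccc(CCCNCc2c(OC)cc(Oc3ccc(Nc4ccccc4)cc3)cc2OC)cc1`, gives 6890 nM
compound 2, `COc1cc(Oc2cccc(Nc3ccccc3)c2)cc(OC)c1CNC1CC1`, gives 12300 nM

Within the data shown here, only two compounds have numbers in this assay, and they differ from each other in more than one place, so no single step can be read between them. Compound 2 is the one with the larger of the two numbers, but its gap to compound 1 lies within the usual scatter, and the two cannot be told apart on this read-out.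

Compound 3, `COc1ccc(CNCc2c(OC)cc(Oc3cccc(Nc4ccccc4)c3)cc2OC)cc1`, is the next compound for this assay. Relative to compound 2 it carries 4-methoxybenzyl in place of cyclopropyl on an amine nitrogen. The shared core of compound 2 and compound 3 is otherwise unchanged.

Among the measured compounds shown here, no measured step speaks directly to this change. The step is expected to be small, toward a lower number, of about a 1.8-fold lower number from compound 2 to compound 3 (0.24 log units; within the scatter), roughly at the edge of the scatter. Compound 3 is estimated at 7000 nM, within a range of 2500 nM to 20000 nM.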

Compound 3, half-maximal inhibitory concentration: 1890 nM
Compound 3: the middle estimate sits 3.7-fold (0.57 log units) above what was measured; the measured number lies below the stated range.
By their numbers in this assay, from the lowest: compound 3; then compounds 1 and 2 (each within the scatter of the next).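

In this assay, among these compounds, the amine nitrogen proves to be a position that responds: 4-methoxybenzyl in place of cyclopropyl gives a 6.5-fold lower number from compound 2 to compound 3 (0.81 log units; beyond the scatter) and this is the first single-place step available. The entering group brings an aromatic ring, a hydrogen-bond acceptor and more heavy atoms than the leaving one, and this single step cannot tell which of these differences counts. Nothing available bears on why the step goes this way.

A plain benzyl on the same nitrogen would separate the contribution of the methoxy group from that of the aromatic ring. On these data alone, whether a phenethyl group on that nitrogen keeps, extends or loses the step also stays open.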